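Aryl ether variation in a piperidine series

A few compounds are considered here, and "the series" means these few. Any claim that something is new, unique, unknown or untested is made for them only; others in the source may bear on it.

Measured compounds:
- compound 1, `Cc1ccc(Oc2cccc(CN3CCC(c4cccc(NC(=O)C(C)C)c4)CC3)c2)cc1`: 31 nM
- compound 2, `CC(C)C(=O)Nc1cccc(C2CCN(Cc3cccc(Oc4ccc(Cl)cc4)c3)CC2)c1`: 23 nM

In an assay on isolated protein for displacement of a labelled ligand from melanin-concentrating hormone receptor 1 (Rattus norvegicus) (a higher number here means a weaker inhibitor, a lower number a stronger inhibitor), compound 1 gives 31 nM, and compound 2 gives 23 nM. Compound 2 has the lower of the two numbers, yet the step of a 1.3-fold lower number from compound 1 to compound 2 (0.13 log units; within the scatter) is within the scatter, so the two cannot be ordered.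

Compound 3, `CC(C)C(=O)Nc1cccc(C2CCN(Cc3cccc(Oc4cccc(C(F)(F)F)c4)c3)CC2)c1`, is not yet measured in this assay. It differs from compound 2 by 3-(trifluoromethyl)phenyl in place of 4-chlorophenyl on an oxygen on an aromatic ring. Within the data shown here, the only measured step, a 1.3-fold lower number from compound 1 to compound 2 (0.13 log units; within the scatter), exchanges a methyl for a chloro on the same ring and leaves the number essentially unchanged. Among the measured compounds shown here, no measured pair exchanges a chloro for a trifluoromethyl, nor moves a substituent around that ring, so the step to compound 3 has no direct precedent. Given that the one variation seen on this ring stayed within the scatter, compound 3 is expected to stay close to compound 2, with the estimated step of a 1.1-fold higher number from compound 2 to compound 3 (0.04 log units; within the scatter). The estimate for compound 3 in this assay is therefore 25 nM, with a range from 8 nM to 80 nM.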

Compound 3, inhibition constant: 65 nM
Beside the measured number, compound 3's estimate is 2.6-fold (0.41 log units) below it, and the stated range covers the measured number.
By their numbers in this assay, from the lowest: compounds 2 and 1 (each within the scatter of the next); then compound 3.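

In this assay, the change to 3-(trifluoromethyl)phenyl on the oxygen gives a 2.8-fold higher number from compound 2 to compound 3 (0.45 log units; beyond the scatter), and the same change made from 4-methylphenyl gives a 2.1-fold higher number from compound 1 to compound 3 (0.32 log units; beyond the scatter), so this position, which had shown no readable difference until now, does respond to the aryl group it carries. Both steps are modest, and they start from two compounds that lie within the scatter of each other, so they describe one shift in the number rather than two separate findings. The data shown offer nothing that accounts for this shift.

The step alters both the substituent and its place on the ring at once, and the compounds shown do not separate these two changes, leaving it open whether the trifluoromethyl group itself or its new place carries the difference. Also open, as far as these compounds go, is how the number would respond to a different kind of group on that ring, such as an amine, a nitrile or a carboxylic acid.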